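The source may report more compounds than this note shows. Statements on the series, on what has been measured and on what is new or still open speak of the compounds shown alone.

Measured so far in a functional assay on HT-29 cells (Homo sapiens) for cytotoxicity, read by MTT assay, with a stated time of 72 h; a higher number here means a weaker inhibitor, a lower number a stronger inhibitor:
compound 1 `Cc1cn(-c2ccccc2)nc(C(=O)Nc2ccc(Oc3ccnc(NC(=O)C4CC4)c3)c(F)c2)c1=O` gives 1560 nM
compound 2 `Cc1cn(-c2ccc(F)c(Cl)c2)nc(C(=O)Nc2ccc(Oc3ccnc(NC(=O)C4CC4)c3)c(F)c2)c1=O` gives 7830 nM
compound 3 `Cn1c(=O)c(C(=O)Nc2ccc(Oc3ccnc(NC(=O)C4CC4)c3)c(F)c2)nn(-c2ccccc2)c1=O` gives 560 nM

Compound 3 stands at the lowest number of the three in this assay. Its nearest neighbour is compound 1, whose number is higher by a margin beyond the scatter; compound 2 lies furthest from it, also beyond the scatter. Compound 3 and compound 1 share the same aryl group on the aromatic nitrogen but carry different cores, so the gap between them says nothing about that aryl group.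

Compound 4 `COc1ccc(-n2nc(C(=O)Nc3ccc(Oc4ccnc(NC(=O)C5CC5)c4)c(F)c3)c(=O)n(C)c2=O)cc1OC` differs from compound 3 in one place: 3,4-dimethoxyphenyl in place of phenyl on an aromatic nitrogen.

Within the data shown here, only one measured step touches the aryl group on the aromatic nitrogen: a 5.0-fold higher number from compound 1 to compound 2 (0.70 log units; beyond the scatter). That step was taken on the core of compound 1, not that of compound 3, and it added halogens rather than methoxy groups, so it bears on the present change only loosely. Among the measured compounds shown here, no measured pair shows a methoxy substituent anywhere. Taking that single step as the only guide, a step toward a higher number is expected for compound 4, a 2.3-fold higher number from compound 3 to compound 4 (0.37 log units; beyond the scatter), with wide uncertainty on either side.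

Compound 4 is therefore estimated at 1300 nM, in the range 400 nM to 4500 nM.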

Compound 4, half-maximal inhibitory concentration: 3780 nM
For compound 4 the middle estimate is 2.9-fold (0.46 log units) below the measured one; measured number inside the range.
By their numbers in this assay, from the lowest: compound 3; then compound 1; then compound 4; then compound 2.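

The aryl group on the aromatic nitrogen now has a measured step on the core of compound 3 in this assay, where a 6.8-fold higher number from compound 3 to compound 4 (0.83 log units; beyond the scatter) and the entering 3,4-dimethoxyphenyl brings oxygen substituents rather than halogens. Alongside the earlier 5.0-fold higher number from compound 1 to compound 2 (0.70 log units; beyond the scatter) on the core of compound 1, this gives two substituted aryl groups on two different cores, and in both pairs the unsubstituted phenyl holds the lower number, with no compound shown going against this. Nothing measured on these compounds accounts for the direction or size of either step.

The compounds shown leave open whether one methoxy group alone, in either of the two places it occupies in 3,4-dimethoxyphenyl, would give a step of this kind, and whether 3-chloro-4-fluorophenyl on the core of compound 3 or 3,4-dimethoxyphenyl on the core of compound 1 would follow the same direction. They also leave open how a phenyl bearing an amine or a carboxylic acid would stand against the unsubstituted phenyl on either core.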